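Removing butyl from the long chain of compound 1

This account rests on a few compounds, and the source may have more. Where it says the series, first, only, none or still open, it means among the compounds named here.

In a functional assay on RAW264.7 cells (Mus musculus) for inhibition, with a stated time of 1 h (a higher number here means a weaker inhibitor, a lower number a stronger inhibitor), compound 1 `CCCCCCCCCCCCCCC(=O)C(=O)N[C@@H](CCCC)CCC(=O)O` gives 25000 nM. Compound 3 `CCCCCCCCCCCCCCC(=O)C(=O)N[C@@H](CCCC)COCC(=O)O` stands level with it at 25000 nM, and the two share the highest number of the three measured, while compound 2 `CCCCCCCCCCCCCCC(=O)C(=O)NCCCC(=O)O` gives 10000 nM. Compound 4 `CCCCCCCCCCC(=O)C(=O)N[C@@H](CCCC)CCC(=O)O` has not yet been measured. It departs from compound 1 by one change: hydrogen in place of butyl on a saturated chain carbon, ten or more bonds along the chain from a carbonyl carbon. Within the data shown here, no measured step touches this part of the long chain. The closest guide is the loss of butyl on a different carbon, one bound to an amide-type nitrogen, which gave a modest change: a 2.5-fold lower number from compound 1 to compound 2 (0.40 log units; beyond the scatter). The other measured step, no change at the digits printed from compound 1 to compound 3 (within the scatter), also lies away from the long chain and stays within the scatter. These two steps give no firm direction for the new change, so no shift beyond the scatter is expected in this assay. The estimated step is no change at the digits printed from compound 1 to compound 4 (within the scatter). The estimated value for compound 4 is 25000 nM, with an expected range of 10000 nM to 60000 nM.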

Compound 4, half-maximal inhibitory concentration: 25000 nM
Estimate against measurement, compound 4: no gap at the digits printed; the measured number falls inside the stated range.
By their numbers in this assay, from the lowest: compound 2; then compounds 1, 3 and 4 (each within the scatter of the next).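

In this assay, among these compounds, the exchange of butyl for hydrogen on a saturated chain carbon reads as no change at the digits printed from compound 1 to compound 4 (within the scatter) and is the first reading at this position, since the earlier steps left the long chain untouched. It shows that, on the core of compound 1, the long chain can lose this butyl without a shift beyond the scatter, so at this position the number does not follow the change in chain length. Nothing available here accounts for this result.

From the compounds shown here alone, whether a longer chain, or an amine or a carboxylic acid at this position, would leave the number equally unmoved remains open. So does whether the same loss of butyl would read alike on compound 2 or compound 3.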